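The compounds below may be only part of what the source reports. "The series", "measured", "known", "first", "only" and "open" are said of these compounds alone.

Measured compounds:
compound 1, `Cc1cc(CCC(=O)O)ccc1-c1noc(-c2ccc(OC(C)C)c(Cl)c2)n1`, in a functional assay on CHO cells with sphingosine 1-phosphate receptor 2 (Homo sapiens) as the target, read by GTPgammaS binding (a lower number here means that less compound is needed, a higher number that more compound is needed for the effect), gives > 10000 nM.
compound 2, `Cc1cc(CCC(=O)O)ccc1-c1noc(-c2ccc(OCC(F)(F)F)c(C#N)c2)n1`, in this assay gives > 10000 nM.
compound 3, `CCCCc1ccc(-c2nc(-c3ccc(CCC(=O)O)cc3C)no2)nc1`, in this assay gives > 10000 nM.

Each of these values is a limit of the assay rather than a number. Compound 3 thus stands where every measured compound stands, at the limit of > 10000 nM in this assay, at which 3 of the 3 values shown sit. Going by the values given here, no measured step between two compounds differing in one place is available.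

Compound 4, `Cc1cc(CCC(=O)O)ccc1-c1noc(-c2ccc(CC(C)C)cn2)n1`, differs from compound 3 by isopropyl in place of propyl on a saturated chain carbon bound to an aromatic carbon. With compound 3 at > 10000 nM, the expected step from compound 3 to compound 4, a step that the limit leaves unreadable from compound 3 to compound 4, is none beyond the scatter. Compound 4 is therefore estimated at 25000 nM, ranging from 8000 nM to 100000 nM, most likely again reported only as a limit.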

Compound 4, half-maximal effective concentration: > 10000 nM
Compound 4: only a limit was reported; the forecaster's own chance of this, stated with the estimate: 85%; the middle value lies beyond the limit too.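

Going by these compounds alone, compound 3 and compound 4 each give only a limit, and no step between them can be read. The compounds shown leave open how far beyond that limit each one lies, and which structural change would bring a value within the range of the assay.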